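Swapping the aryl tail on a shared pyrrolidinylmethyl-bearing core

The compounds below may be only part of what the source reports. "The series", "measured", "known", "first", "only" and "open" are said of these compounds alone.

Measured compounds:
- Compound 1, `CN1CCC[C@@H]1Cn1nc(CC2CCCCC2)c2ccccc2c1=O`, in an assay for binding affinity to Alpha-1B adrenergic receptor (Homo sapiens); a higher number here means a weaker inhibitor, a lower number a stronger inhibitor: > 1990 nM
- Compound 2, `CN1CCC[C@@H]1Cn1nc(CCc2ccccc2)c2ccccc2c1=O`: 200 nM
- Compound 3, `CN1CCC[C@@H]1Cn1nc(Cc2ccc(F)cc2)c2ccccc2c1=O`: 79.4 nM

The value of compound 1 is a limit of the assay, not a number (the limit of > 1990 nM in this assay, at which 1 of the 3 values shown sits). Among the two real numbers, compound 3 holds the lowest; compound 2 sits a 2.5-fold lower number from compound 2 to compound 3 (0.40 log units; beyond the scatter). Compound 1, with cyclohexyl, gives an at least 9.9-fold lower number from compound 1 to compound 2 (0.99 log units; beyond the scatter) and an at least 25-fold lower number from compound 1 to compound 3 (1.39 log units; beyond the scatter), so the move from a saturated ring to an aryl group was the decisive one, while the further change within the aryl set was modest.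

Compound 4, `COc1cccc(Cc2nn(C[C@H]3CCCN3C)c(=O)c3ccccc23)c1`, is not yet measured. It differs from compound 3 as follows: 3-methoxyphenyl in place of 4-fluorophenyl on a saturated chain carbon bound to an aromatic carbon. This is a change within the aryl set, of the same kind as the step from compound 2 to compound 3, which was modest. For the measured compounds named here, no measured step shows a 3-methoxyphenyl here, so the direction is open; the aryl group is kept, and a step within or barely beyond the scatter is expected, a 1.6-fold higher number from compound 3 to compound 4 (0.20 log units; within the scatter). Compound 4 is therefore estimated at 125 nM, within a range of 40 nM to 400 nM.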

Compound 4, inhibition constant: > 1990 nM
Compound 4 gave a limit, no number (the forecaster's own chance of this, stated with the estimate: 5%); middle value at least 15-fold (1.20 log units) from the limit.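

In this assay compound 4 gives > 1990 nM, which is a limit of the assay and not a number, and compound 4 now shares that limit with compound 1: the limit of > 1990 nM in this assay, at which 2 of the 4 values shown sit. Keeping an aryl group on the saturated chain carbon bound to an aromatic carbon therefore did not by itself keep the number low, as shown by an at least 25-fold higher number from compound 3 to compound 4 (1.39 log units; beyond the scatter) and an at least 9.9-fold higher number from compound 2 to compound 4 (0.99 log units; beyond the scatter), so the change from 4-fluorobenzyl to 3-methoxybenzyl matters far more than the earlier step within the aryl set, a 2.5-fold lower number from compound 2 to compound 3 (0.40 log units; beyond the scatter). The step between compound 1 and compound 4 cannot be read, as both values are limits.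

The compounds shown do not separate the methoxy group from its placement: a 4-methoxyphenyl or a 3-fluorophenyl group at this place would do so. From the compounds shown here alone, how an unsubstituted phenyl or a 3-hydroxyphenyl group would read in this assay also stays open.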